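The source may hold more compounds than are shown below. What is called first, only, known or untested is meant among the compounds shown, and "the series" means these compounds.

Compound 2 `CCC(=O)N1CCc2cc(CNC(=O)c3ccnn3C)ccc21` stands lowest of the two compounds measured in an assay on HEK293 cells for inhibition of Indoleamine 2,3-dioxygenase 1 (Homo sapiens), tested at 10 uM (a lower number here means less inhibition, a higher number more inhibition at the concentration tested (going by the name of the read-out)), where compound 2 gives 14%; compound 1 `CCC(=O)N1CCc2cc(CNC(=O)c3cccs3)ccc21` gives 89%. Among the measured compounds shown here, the single step measured so far, a number 75 percentage points lower from compound 1 to compound 2 (beyond the scatter), put 1-methyl-1H-pyrazol-5-yl in place of thiophen-2-yl on a carbonyl carbon. Compound 3 `CCC(=O)N1CCc2cc(CNC(=O)c3ccccc3)ccc21` differs from compound 2 by phenyl in place of 1-methyl-1H-pyrazol-5-yl on a carbonyl carbon. Phenyl itself has not been tested, so the measured step only suggests that leaving the pyrazole behind could restore much of the inhibition lost in compound 2. Compound 3 is expected to give about 70%, within 35% to 95%, a rise of a number 56 percentage points higher from compound 2 to compound 3 (beyond the scatter).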

Compound 3, a percentage reported as inhibition, at one concentration (the size of the read-out at that concentration, not a potency): 87%
Compound 3: middle estimate off by 17 percentage points, on the low side; the range from low to high includes it.
By their numbers in this assay, from the lowest: compound 2; then compounds 3 and 1 (each within the scatter of the next).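

Phenyl in place of 1-methyl-1H-pyrazol-5-yl on the carbonyl carbon gives a number 73 percentage points higher from compound 2 to compound 3 (beyond the scatter), so the inhibition lost in compound 2 returns without any thiophen-2-yl. Phenyl in place of thiophen-2-yl gives a number 2 percentage points lower from compound 1 to compound 3 (within the scatter), which means the sulfur-containing ring is not needed in this assay and, of these three rings, only 1-methyl-1H-pyrazol-5-yl stands apart. Nothing given here explains why the pyrazole behaves differently.

Still open, on these data alone, is whether the loss follows the ring nitrogens or the methyl group of the pyrazole. As far as these compounds go, how a pyridine ring or a cyclohexyl group would fare at this carbonyl carbon also remains unknown.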